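Nitro for chloro on the hydrazone aryl group

This account rests on a few compounds, and the source may have more. Where it says the series, first, only, none or still open, it means among the compounds named here.

The three measured compounds share a core and differ in the aryl group on the hydrazone and in the thioether chain. In a functional assay on MGC-803 cells (Homo sapiens) for antiproliferative activity, read by MTT assay, with a stated time of 72 h (on this read-out lower numbers stand for stronger inhibition and higher numbers for weaker inhibition), compound 2 `CCCSc1nc(N/N=C/c2ccccc2Cl)c2nnn(Cc3ccccc3)c2n1` gives 10900 nM, the highest of the three numbers. Compound 1 `C#CCSc1nc(N/N=C/c2ccc(N(C)C)cc2)c2nnn(Cc3ccccc3)c2n1` gives 7620 nM in this assay, a number within the scatter of that of compound 2, so no order between the two can be read. Compound 3 `COc1cc(/C=N/Nc2nc(SCc3ccccc3)nc3c2nnn3Cc2ccccc2)cc(OC)c1OC` gives 1320 nM in this assay, a lower number than compound 2 by a gap beyond the scatter; it also carries a different thioether, so the aryl change alone cannot be credited.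

Compound 4 `CCCSc1nc(N/N=C/c2ccc([N+](=O)[O-])cc2)c2nnn(Cc3ccccc3)c2n1` keeps the thioether of compound 2 and differs only on the hydrazone aryl group: 4-nitrophenyl in place of 2-chlorophenyl on a carbon with a double bond to nitrogen. Going by the values given here, no measured pair shows this change, so its size is unknown. Compound 4 is expected to give about 7000 nM in this assay, within 2500 nM to 20000 nM. The step of a 1.6-fold lower number from compound 2 to compound 4 (0.19 log units; within the scatter) that this estimate means is expected to stay within the scatter, with no clear direction.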

Compound 4, half-maximal inhibitory concentration: 10100 nM
Compound 4: middle estimate off by 1.4-fold (0.16 log units), on the low side; measured number inside the range.
By their numbers in this assay, from the lowest: compound 3; then compounds 1, 4 and 2 (each within the scatter of the next).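

With the thioether of compound 2 held fixed, the aryl group on the hydrazone can finally be judged on its own. In this assay placing 4-nitrophenyl in place of 2-chlorophenyl on a carbon with a double bond to nitrogen gives a 1.1-fold lower number from compound 2 to compound 4 (0.03 log units; within the scatter) and so leaves no readable difference, which means this position accepts either aryl group without a clear change in the number. No measurement at hand offers any explanation for this result.

Compound 3 differs from the others in both its aryl group and its thioether, so what lies behind its lower number stays open. Also open, on these data alone, is whether an amine or a carboxylic acid on the aryl ring, or a longer chain on the sulfur, would move the number beyond the scatter.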